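The source may hold more compounds than are shown below. What is called first, only, known or untested is meant among the compounds shown, and "the series" means these compounds.

In a functional assay on A549 cells (Homo sapiens) for antiproliferative activity, read by MTT assay (a higher number here means a weaker inhibitor, a lower number a stronger inhibitor), compound 2 `Cc1cc(C)c(/C=N/Nc2ncc3c(n2)n(C2CCCC2)c(=O)c(=O)n3C)c(C)c1` gives 12000 nM, the lowest of the three numbers recorded. Compound 3 `COc1cc(/C=N/Nc2ncc3c(n2)n(C2CCCC2)c(=O)c(=O)n3C)cc(OC)c1OC` gives 18300 nM, a gap within the scatter, while compound 1 `Cn1c(=O)c(=O)n(C2CCCC2)c2nc(N/N=C/c3cccc(Cl)c3Cl)ncc21` gives 39100 nM; the step of a 3.3-fold lower number from compound 1 to compound 2 (0.51 log units; beyond the scatter) is the only measured one that bears on a change on the carbon with a double bond to nitrogen. Compound 4 `CSc1ccc(/C=N/Nc2ncc3c(n2)n(C2CCCC2)c(=O)c(=O)n3C)cc1` differs from compound 2 by 4-(methylsulfanyl)phenyl in place of 2,4,6-trimethylphenyl on a carbon with a double bond to nitrogen. Because that comparable change gave only a 3.3-fold lower number from compound 1 to compound 2 (0.51 log units; beyond the scatter), and the two aryl groups of compound 2 and compound 3 sit within the scatter of each other, the expected step is a 1.3-fold higher number from compound 2 to compound 4 (0.12 log units; within the scatter), not clearly beyond the scatter. The estimate for compound 4 is therefore 16000 nM, within 6000 nM to 40000 nM.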

Compound 4, half-maximal inhibitory concentration: 14100 nM
Beside the measured number, compound 4's estimate is 1.1-fold (0.05 log units) above it, and the stated range covers the measured number.
By their numbers in this assay, from the lowest: compounds 2, 4 and 3 (each within the scatter of the next); then compound 1.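

The change at this position shows a 1.2-fold higher number from compound 2 to compound 4 (0.07 log units; within the scatter) in this assay so a 4-(methylsulfanyl)phenyl, which brings in a sulfur atom and a hydrogen-bond acceptor, reads no differently from the 2,4,6-trimethylphenyl. Replacing the 2,3-dichlorophenyl gives a 2.8-fold lower number from compound 1 to compound 4 (0.44 log units; beyond the scatter) and this second step beyond the scatter sets compound 1 apart from both compound 2 and compound 4. Nothing measured here accounts for these steps. As far as these compounds go, all four compounds carry a substituted phenyl ring on this carbon, so a phenyl bearing an amine or a carboxylic acid, or an alkyl chain in place of the ring, remains open.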